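Swapping Thiazole for Imidazole on a Diaryl Urea Scaffold

A few compounds are considered here, and "the series" means these few. Any claim that something is new, unique, unknown or untested is made for them only; others in the source may bear on it.

Compounds 1, 2 and 3 share one core and differ only in the aryl group on one urea nitrogen. In a functional assay on A549 cells (Homo sapiens) for inhibition, read by MTT assay and WST assay, with a stated time of 72 h (a higher number here means a weaker inhibitor, a lower number a stronger inhibitor), compound 1 `O=C(Nc1ccc(Oc2ccc(-c3nccs3)cc2)cc1)Nc1ccc(Cl)c([N+](=O)[O-])c1` gives 3890 nM. Compound 2 `O=C(Nc1ccc(Oc2ccc(-c3nccs3)cc2)cc1)Nc1ccc(F)c(C(F)(F)F)c1` gives 4980 nM in this assay, and compound 3 `O=C(Nc1ccc(Oc2ccc(-c3nccs3)cc2)cc1)Nc1cc(C(F)(F)F)ccc1Cl` gives 7040 nM. On these numbers compound 2 sits between the other two, nearer to compound 1 than to compound 3, yet every step among them, a 1.3-fold higher number from compound 1 to compound 2 (0.11 log units; within the scatter), a 1.8-fold higher number from compound 1 to compound 3 (0.26 log units; within the scatter) and a 1.4-fold higher number from compound 2 to compound 3 (0.15 log units; within the scatter), lies within the scatter, so the three compounds cannot be told apart.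

Compound 4 `O=C(Nc1ccc(Oc2ccc(-c3ncc[nH]3)cc2)cc1)Nc1ccc(F)c(C(F)(F)F)c1` keeps the aryl group of compound 2 and alters the opposite end of the molecule: 1H-imidazol-2-yl in place of 1,3-thiazol-2-yl on an aromatic carbon. Among the measured compounds shown here, none of the measured steps touches this part of the structure; all of them concern the aryl group on the urea nitrogen, and all of them stayed within the scatter. For the measured compounds named here, no measured step therefore bears directly on the change from compound 2 to compound 4. With nothing to point either way, the expected step is a 1.0-fold higher number from compound 2 to compound 4 (0.00 log units; within the scatter), that is, no change beyond the scatter, carried with a wide range. Compound 4 is estimated at 5000 nM, between 1800 nM and 14000 nM.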

Compound 4, half-maximal inhibitory concentration: 10500 nM
For compound 4 the middle estimate is 2.1-fold (0.32 log units) below the measured one; the range from low to high includes it.
By their numbers in this assay, from the lowest: compounds 1, 2, 3 and 4 (each within the scatter of the next, the first and the last beyond it).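

Among the compounds shown here, every earlier step concerned the aryl group on the urea nitrogen and stayed within the scatter, whereas in this assay the exchange at the opposite end, on an aromatic carbon para to a large group, gives a 2.1-fold higher number from compound 2 to compound 4 (0.32 log units; beyond the scatter) and is the first step here to pass beyond it, though only modestly. This end of the molecule is therefore not indifferent to change: 1H-imidazol-2-yl in place of 1,3-thiazol-2-yl makes the number higher, even though both are five-membered aromatic rings of the same heavy-atom count with two hetero atoms, differing in that nitrogen replaces sulfur and the entering group carries a hydrogen-bond donor that the leaving group lacks. Nothing available indicates which of these differences lies behind the step.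

For the compounds shown here, this exchange is seen with only one aryl group on the urea nitrogen, so it remains open whether it would give a similar step with the 4-chloro-3-nitrophenyl group of compound 1 or the 2-chloro-5-(trifluoromethyl)phenyl group of compound 3. As far as these compounds go, it is also open how a 1,3-oxazol-2-yl group or a 1-methyl-1H-imidazol-2-yl group would read at this place.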